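Benzyl to cyclohexyl on the amide nitrogen: cytotoxicity outlook

The source may hold more compounds than are shown below. What is called first, only, known or untested is meant among the compounds shown, and "the series" means these compounds.

Compound 1 `C=CC1=C(C(=O)NCc2ccccc2)C(c2ccc(OC)c(OC)c2)OC1`, compound 2 `C=CC1=C(C(=O)NCc2ccccc2)C(c2ccc(OC)cc2)OC1` and compound 3 `C=CC1=C(C(=O)Nc2ccc(C)cc2)C(c2ccc(F)cc2)OC1` share one core and have all been run in a functional assay on HeLa cells (Homo sapiens) for cytotoxicity, read by MTT assay, with a stated time of 24 h; a lower number here means a stronger inhibitor, a higher number a weaker inhibitor. In this assay compound 1 reaches only a limit of the assay, > 100000 nM. In this assay compound 2 likewise gives only a limit, > 100000 nM. In this assay compound 3 also stops at a limit, > 100000 nM. Compound 2 thus stands at a limit rather than at a number, as do the other two; (the limit of > 100000 nM in this assay, at which 3 of the 3 values shown sit). Going by the values given here, the one step between measured compounds that differ in a single place, a step that the two limits leave unreadable from compound 1 to compound 2, is for that reason of unreadable size. Compound 4 `C=CC1=C(C(=O)NC2CCCCC2)C(c2ccc(OC)cc2)OC1` has not been measured; it differs from compound 2 by cyclohexyl in place of benzyl on an amide-type nitrogen. Among the compounds with values here, no measured step bears on this change directly, and the only step that exists gives no readable size; with all three values at the limit, no shift beyond the scatter in this assay can be expected in either direction. The estimate for compound 4 is 150000 nM, between 50000 nM and 500000 nM, most likely reported again as a limit. The step this estimate means is expected to be a step that the limit leaves unreadable from compound 2 to compound 4.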

Compound 4, half-maximal inhibitory concentration: 24800 nM
For compound 4 the middle estimate is 6.0-fold (0.78 log units) above the measured one, outside the stated range (below it).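

In this assay, going by these compounds alone, cyclohexyl in place of benzyl on the amide nitrogen gives an at least 4.0-fold lower number from compound 2 to compound 4 (0.60 log units; beyond the scatter), the only readable step; the step between the methoxy compounds cannot be read. Within the data shown here, this shows that the group on the amide nitrogen can move the read-out off the limit, which the earlier compounds could not show. Compound 4 is the only compound here with a number rather than a limit, and the others stay at the ceiling: the limit of > 100000 nM in this assay, at which 3 of the 4 values shown sit.

As far as these compounds go, the full size of the step remains unknown, as compound 2 gives only a limit, and it is unclear whether the shift would carry over to the dimethoxy pattern of compound 1. Also open, from the compounds shown here alone, is how cyclopentyl, a longer chain such as n-hexyl, or a cyclohexyl carrying an amine would behave on the amide nitrogen.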